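Allyloxy for dimethylamino on a triazine imine: cytotoxicity outlook

The source may report more compounds than this note shows. Statements on the series, on what has been measured and on what is new or still open speak of the compounds shown alone.

Measured compounds: compound 1 `COc1nc(C)nc(/N=C/c2ccc(N(C)C)cc2)n1`, > 50 ug/mL; compound 2 `COc1nc(C)nc(/N=C/c2cc(Cl)cc(Br)c2O)n1`, > 50 ug/mL.

Compound 1 stands only at a limit of an ADME assay on Vero cells (Chlorocebus sabaeus) for cytotoxicity, read by MTT assay, with a stated time of 72 h; a higher number here means a weaker inhibitor, a lower number a stronger inhibitor: its value of > 50 ug/mL is a limit, not a number. Compound 2, `COc1nc(C)nc(/N=C/c2cc(Cl)cc(Br)c2O)n1`, likewise gives only the limit > 50 ug/mL. Both values sit at the limit of > 50 ug/mL in this assay, at which 2 of the 2 values shown sit. Compound 3, `C=CCOc1ccc(/C=N/c2nc(C)nc(OC)n2)cc1`, differs from compound 1 by allyloxy in place of dimethylamino on an aromatic carbon. Among the compounds with values here, no measured step resembles this change, so compound 3 is expected to remain at the limit, with no step beyond the scatter, and its value is estimated at 100 ug/mL (range 40 ug/mL to 300 ug/mL); the step that the limit leaves unreadable from compound 1 to compound 3 is an expectation only.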

Compound 3, half-maximal inhibitory concentration: > 50 ug/mL
Compound 3: only a limit was reported (the forecaster's own chance of this, stated with the estimate: 85%); the middle value does not contradict the limit.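

Within the data shown here, compound 1 and compound 3 both stand only at a limit in this assay, so no step between them can be read. The compounds shown leave open at what concentration, if any, cytotoxicity would reach half-maximal inhibition: the limit of > 50 ug/mL in this assay, at which 3 of the 3 values shown sit.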